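Adding 2,3-dihydroxyphenyl to a compound known only by a limit

The source may report more compounds than this note shows. Statements on the series, on what has been measured and on what is new or still open speak of the compounds shown alone.

In a functional assay on RAW264.7 cells (Mus musculus) for inhibition (a lower number here means a stronger inhibitor, a higher number a weaker inhibitor), compound 1 (`C=C[C@H]1[C@H](O[C@@H]2O[C@H](COC(C)=O)[C@@H](O)[C@H](OC(C)=O)[C@H]2OC(C)=O)OC=C2C(=O)OCC[C@H]21`) gives > 200000 nM as its reading, which is a limit and not a number. Compound 2 (`C=C[C@H]1[C@H](O[C@@H]2O[C@H](COC(C)=O)[C@@H](OC(C)=O)[C@H](OC(C)=O)[C@H]2O)OC=C2C(=O)OCC[C@H]21`) gives > 200000 nM as its reading, again a limit. Among the compounds with values here, that leaves the limit of > 200000 nM in this assay, at which 2 of the 2 values shown sit, as the whole of the evidence, and no step between measured compounds is available.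

Compound 3 (`C=C[C@H]1[C@H](O[C@@H]2O[C@H](COC(C)=O)[C@@H](O)[C@H](OC(C)=O)[C@H]2OC(=O)c2cccc(O)c2O)OC=C2C(=O)OCC[C@H]21`) differs from compound 1 by 2,3-dihydroxyphenyl in place of methyl on a carbonyl carbon in a single change: 2,3-dihydroxyphenyl in place of methyl on a carbonyl carbon. Since compound 1 reads > 200000 nM as a limit, a modest move toward stronger inhibition in this assay is expected, though a reading at the same limit remains possible. The expected step of an at least 3.3-fold lower number from compound 1 to compound 3 (0.52 log units; beyond the scatter) is an estimate that starts from a limit. For compound 3 the estimated value is 60000 nM with 15000 nM to 200000 nM as its expected range.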

Compound 3, half-maximal inhibitory concentration: > 200000 nM
Compound 3: only a limit was reported; the forecaster's own chance of this, stated with the estimate: 35%; middle value at least 3.3-fold (0.52 log units) from the limit.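

In this assay compound 3 gives > 200000 nM, which is again a limit. Within the data shown here, compound 1 also stands at a limit, and no step from compound 1 to compound 3 can be read. Still open, going by these compounds, is whether 2,3-dihydroxyphenyl in place of methyl changes inhibition at all.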